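Urea series: aryl ether change at the cyclohexyl oxygen

The source may hold more compounds than are shown below. What is called first, only, known or untested is meant among the compounds shown, and "the series" means these compounds.

Measured so far:
compound 1, `COc1ccccc1NC(=O)N[C@H]1CC[C@H](Oc2ccc(F)cc2)CC1`: > 20000 nM
compound 2, `O=C(Nc1cccc(C(F)(F)F)c1)N[C@H]1CC[C@H](Oc2cccc(F)c2)CC1`: 2400 nM
compound 3, `O=C(Nc1cccc(C(F)(F)F)c1)N[C@H]1CC[C@@H](Oc2ccc(F)cc2)CC1`: 2600 nM

The read-out throughout is a functional assay on CRL2813 cells (Homo sapiens) for cytotoxicity, read by sulforhodamine B assay, with a stated time of 5 days; on this read-out lower numbers stand for stronger inhibition and higher numbers for weaker inhibition. Compound 1 gives only a limit in this assay, > 20000 nM, so no number is known for it; this is recorded as the limit of > 20000 nM in this assay, at which 1 of the 3 values shown sits. Compound 2 gives 2400 nM in this assay, the lowest of the two numbers shown, and compound 3 gives 2600 nM; the two values sit within the scatter of each other, so no order between compound 2 and compound 3 can be drawn from them.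

Compound 4, `O=C(Nc1cccc(C(F)(F)F)c1)N[C@H]1CC[C@H](Oc2ccc(C(F)(F)F)cc2)CC1`, is not yet measured in this assay. It differs from compound 2 in one place: 4-(trifluoromethyl)phenyl in place of 3-fluorophenyl on an oxygen on a saturated carbon. Among the compounds with values here, no step between measured compounds isolates a change of this kind, so there is no measured reference for its size. The nearest measured pair, compound 2 and compound 3, shows that a fluorine at either position of the aryl ether leaves the number essentially unchanged, which suggests this part of the molecule tolerates variation.

The expected step in this assay from compound 2 to compound 4 is a 1.2-fold lower number from compound 2 to compound 4 (0.08 log units; within the scatter), that is, none beyond the scatter. For compound 4 the estimate in this assay is 2000 nM, with a range from 600 nM to 7000 nM.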

Compound 4, half-maximal inhibitory concentration: 460 nM
Estimate against measurement, compound 4: 4.3-fold (0.64 log units) above; measured number outside the range, below it.
By their numbers in this assay, from the lowest: compound 4; then compounds 2 and 3 (each within the scatter of the next). At a limit, above all of these: compound 1.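

In this assay, the aryl group on the oxygen on a saturated carbon proves able to shift the number: 4-(trifluoromethyl)phenyl in place of 3-fluorophenyl gives a 5.2-fold lower number from compound 2 to compound 4 (0.72 log units; beyond the scatter). Within the data shown here, this is the first readable step at this position, and because it lies beyond the scatter, the position cannot be treated as one where changes leave the number untouched. The substituent and its place on the aromatic ring change together in this swap, so this one step cannot say which of the two carries the difference.

Still open, as far as these compounds go, is whether 3-(trifluoromethyl)phenyl on the core of compound 2 would separate those two changes, and whether a nitrile or a methoxy group in place of the trifluoromethyl group of compound 4 would hold the lower number. Nothing in the data at hand bears on the cause of the step, which therefore stands as an observation only.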